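The compounds below may be only part of what the source reports. "The series", "measured", "known", "first", "only" and "open" are said of these compounds alone.

Measured in a functional assay on U-87MG ATCC cells for inhibition, with U-87 MG (Homo sapiens) as the target, read by MTT assay, with a stated time of 48 h; on this read-out lower numbers stand for stronger inhibition and higher numbers for weaker inhibition:
compound 1 `COc1cc(/C=N/Nc2nc(-c3ccc(F)c(F)c3)cs2)cc(Br)c1OC` gives 26300 nM
compound 2 `COc1cc(/C=N/Nc2nc(-c3ccc(F)c(F)c3)cs2)c(Br)c(Br)c1OC` gives 19600 nM
compound 3 `COc1cc(/C=N/Nc2nc(-c3ccc(C(F)(F)F)cc3)cs2)cc(Br)c1OC` gives 41000 nM

Compound 1 sits among these three numbers, and neither of the other two lies beyond the usual scatter from it. The change followed here leads to compound 4 `COc1ccccc1-c1csc(N/N=C/c2cc(Br)c(OC)c(OC)c2)n1` and puts 2-methoxyphenyl in place of 3,4-difluorophenyl on an aromatic carbon, next to the ring nitrogen (2-methoxyphenyl in place of 3,4-difluorophenyl on an aromatic carbon). Within the data shown here, the only measured single-site step is bromo in place of hydrogen on an aromatic carbon, which came to a 1.3-fold lower number from compound 1 to compound 2 (0.13 log units; within the scatter) and lies at another place in the molecule. Closer to the change is compound 3, which carries a different group at the same carbon and gives 41000 nM in this comparison, with compound 1 at 26300 nM and the gap within the scatter. Among the measured compounds shown here, no measured compound carries 2-methoxyphenyl. These numbers give no reason to expect a move beyond the scatter in this assay in either direction. The expected step is a 1.1-fold higher number from compound 1 to compound 4 (0.03 log units; within the scatter) and it stays within the scatter. Compound 4 is estimated at 28000 nM with 12000 nM as the expected lower end and 60000 nM as the expected upper end of the range.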

Compound 4, half-maximal inhibitory concentration: > 100000 nM
Compound 4: no number, only a limit; the forecaster's own chance of this, stated with the estimate: 10%; middle value at least 3.5-fold (0.55 log units) away from the limit.
By their numbers in this assay, from the lowest: compounds 2, 1 and 3 (each within the scatter of the next, the first and the last beyond it). At a limit, above all of these: compound 4.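

In this assay, replacing 3,4-difluorophenyl with 2-methoxyphenyl on this carbon gives an at least 3.8-fold higher number from compound 1 to compound 4 (0.58 log units; beyond the scatter). Compound 1 and compound 3, which also differ at this carbon, had stayed within the scatter of each other, so only now does this position show that the group it carries can clearly weaken inhibition. For compound 4, > 100000 nM is a limit of the assay and not a number: the limit of > 100000 nM in this assay, at which 1 of the 4 values shown sits.

Among these compounds, the single step cannot separate the loss of the two fluorines from the arrival of the methoxy group, and the limit leaves its full size unknown. On these data alone, whether a plain phenyl, or a phenyl carrying an amine or a carboxylic acid, would read like compound 1 or like compound 4 also stays open.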